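The source may report more compounds than this note shows. Statements on the series, on what has been measured and on what is new or still open speak of the compounds shown alone.

In an assay for displacement of a labelled ligand from Sigma non-opioid intracellular receptor 1 (Cavia porcellus), read by scintillation counting (a lower number here means a stronger inhibitor, a higher number a weaker inhibitor), the three measured compounds give these numbers:
Compound 1 `CNCC[C@@H]1CCO[C@H](c2ccccc2)O1` gives 449 nM.
Compound 2 `c1ccc(CNCC[C@@H]2CCO[C@H](c3ccccc3)O2)cc1` gives 19 nM.
Compound 3 `CC[C@@]1(c2ccccc2)OCC[C@@H](CCNC)O1` gives 856 nM.

Compound 3 has the highest number of the three, though its distance from compound 1 is small: a 1.9-fold higher number from compound 1 to compound 3 (0.28 log units; within the scatter). Against compound 2 the gap is wide, as the two values show. Compound 4 `CC[C@@]1(c2ccccc2)OCC[C@@H](CCNCc2ccccc2)O1` differs from compound 3 in one place: phenyl in place of hydrogen on a saturated chain carbon bound to an amine nitrogen. The same change has been measured once already, between compound 1 and compound 2, where it gave a 24-fold lower number from compound 1 to compound 2 (1.37 log units; beyond the scatter). Among the measured compounds shown here, that single step is the only guide available, and it points to a large fall in the number when the same change is made on compound 3. A step of about that size is expected for compound 4, a 24-fold lower number from compound 3 to compound 4 (1.38 log units; beyond the scatter). Compound 4 is therefore expected to give 36 nM in this assay, with a likely range from 12 nM to 110 nM.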

Compound 4, inhibition constant: 27 nM
Compound 4: the middle estimate sits 1.3-fold (0.12 log units) above what was measured, and the stated range covers the measured number.
By their numbers in this assay, from the lowest: compounds 2 and 4 (each within the scatter of the next); then compounds 1 and 3 (each within the scatter of the next).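

The change from methylamino to benzylamino now has a second example, on the core of compound 3, and again the number falls by a large step, a 32-fold lower number from compound 3 to compound 4 (1.50 log units; beyond the scatter). The size of this step is therefore not tied to one core, at least across these four compounds: the same change on two cores in this assay, a 24-fold lower number (1.37 log units; beyond the scatter) from compound 1 to compound 2 and a 32-fold lower number (1.50 log units; beyond the scatter) from compound 3 to compound 4, 1.3-fold (0.13 log units) apart, within the scatter of two such steps. With benzylamino present, ethyl in place of hydrogen on the saturated ring carbon still gives no step beyond the scatter, a 1.4-fold higher number from compound 2 to compound 4 (0.15 log units; within the scatter), so in these compounds neither change visibly alters the effect of the other: the same change on two cores in this assay, a 1.9-fold higher number (0.28 log units; within the scatter) from compound 1 to compound 3 and a 1.4-fold higher number (0.15 log units; within the scatter) from compound 2 to compound 4, 1.3-fold (0.13 log units) apart, within the scatter of two such steps.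

As far as these compounds go, whether phenethylamino in place of benzylamino, or a pyridine ring in place of the phenyl, would keep such a low number in this assay stays open. The same holds for propyl in place of ethyl on the saturated ring carbon.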